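The source may report more compounds than this note shows. Statements on the series, on what has been measured and on what is new or still open speak of the compounds shown alone.

Working notes on the series. In a functional assay on MCF7 cells (Homo sapiens) for cytotoxicity, read by MTT assay, with a stated time of 48 h, tested at 100 uM (on this read-out higher numbers stand for more inhibition of growth at the one concentration tested and lower numbers for less inhibition of growth), compound 1 (`C#CCNC(=O)Nc1cccc(COc2ccc(C(=O)OC)cc2)c1`) gives 30% and compound 2 (`C#CCNC(=O)Nc1cccc(CNCc2ccc(C)cc2)c1`) gives 30%, so compound 2 stands level with compound 1 within the scatter. Compound 3 (`C#CCNC(=O)Nc1cccc(CNCc2ccc(OC(F)(F)F)cc2)c1`) carries trifluoromethoxy in place of methyl on an aromatic carbon, para to a large group: trifluoromethoxy in place of methyl on an aromatic carbon. Among the compounds with values here, no measured pair differs in one place, so no measured step sizes this change. The expected change is a number 5 percentage points higher from compound 2 to compound 3 (within the scatter), estimated as a small rise in this assay that stays close to the scatter. For compound 3 the estimated value is 35%, with an expected range of 15% to 55%.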

Compound 3, percent growth inhibition at one concentration: 30%
Compound 3: middle estimate off by 5 percentage points, on the high side; low and high end bracket the measured number.
By their numbers in this assay, from the lowest: compounds 1, 2 and 3 (each within the scatter of the next).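

In this assay the series gains its first comparison in one place: trifluoromethoxy in place of methyl on an aromatic carbon, para to a large group, gives no change at the digits printed from compound 2 to compound 3 (within the scatter). This position therefore accepts a group of more heavy atoms, with a hydrogen-bond acceptor added, without a shift beyond the scatter at the one concentration tested. No measurement shown offers an explanation for this result.

On these data alone, whether an amine or a carboxylic acid at this position would move the read-out remains open. So does the effect of a longer chain there.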